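Methoxy for Trifluoromethyl on Two Related Cores

A few compounds are considered here, and "the series" means these few. Any claim that something is new, unique, unknown or untested is made for them only; others in the source may bear on it.

Compound 1, `O=C1C(Nc2ccc(C(F)(F)F)cc2)=CC(=O)c2c1nc1n2[C@H]2OC[C@@H](O)[C@H]2OC1`, in a functional assay on MCF7 cells (Homo sapiens) for inhibition, read by sulforhodamine B assay; on this read-out higher numbers stand for weaker inhibition and lower numbers for stronger inhibition: > 4000 nM, a limit of the assay.
Compound 2, `COc1ccc(NC2=CC(=O)c3c(nc4n3[C@H]3OC[C@@H](O)[C@H]3OC4)C2=O)cc1`, in this assay: 4470 nM.
Compound 3, `O=C1C=C(Nc2ccc(C(F)(F)F)cc2)C(=O)c2c1nc1n2[C@H]2OC[C@@H](O)[C@H]2OC1`, in this assay: > 4000 nM, a limit of the assay.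

Compound 1 and compound 3 are built from the same atoms joined differently; the difference between the two cores is not broken down here. For compound 3 only a limit is known in this assay, and one further value in the set is likewise a limit.

The step from compound 1 to compound 2 is methoxy in place of trifluoromethyl on an aromatic carbon. Its size, a step that the limit leaves unreadable from compound 1 to compound 2, is not readable because the limit of > 4000 nM in this assay, at which 2 of the 3 values shown sit, is where compound 1 sits.

Compound 4, `COc1ccc(NC2=CC(=O)c3nc4n(c3C2=O)[C@H]2OC[C@@H](O)[C@H]2OC4)cc1`, is the not yet measured partner of compound 3. It differs from compound 3 by methoxy in place of trifluoromethyl on an aromatic carbon, which is the same change as that from compound 1 to compound 2, at a place described in the same words. Since compound 3 is known only as a limit, the step to compound 4 cannot be anchored at its start; what is known is that the same change on the other core ends at compound 2 with a measurable but weak value.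

In this assay compound 4 is therefore expected to give about 5000 nM, with a range from 2500 nM to 12000 nM, because compound 2 gives 4470 nM after the same change. The expected step that the limit leaves unreadable from compound 3 to compound 4 rests on that single measured outcome and carries a real chance of coming back as another limit.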

Compound 4, half-maximal inhibitory concentration: 5420 nM
Compound 4: the middle estimate sits 1.1-fold (0.04 log units) below what was measured; low and high end bracket the measured number.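

Compound 4 now has a measured value, but the step from compound 3 to compound 4 still cannot be read, because compound 3 is known only as a limit of the assay: the limit of > 4000 nM in this assay, at which 2 of the 4 values shown sit. The compounds shown leave open how large the change from trifluoromethyl to methoxy is on either core; compound 1 and compound 3 both stand only as limits.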